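Compound 2 to compound 3: removing the ring methyl

The source may report more compounds than this note shows. Statements on the series, on what has been measured and on what is new or still open speak of the compounds shown alone.

Compound 1 `O=C(Nc1ccccc1)c1cnc(NCc2c(F)ccc3c2CCO3)n2cnnc12` gives < 1000 nM in a physicochemical assay for solubility, read by LC-MS, in phosphate buffer, with a stated time of 24 h, at pH 7.4 (on this read-out lower numbers stand for lower solubility and higher numbers for higher solubility), which is a limit of the assay and not a number. Among the measured compounds shown here, compound 2 `C[C@H]1CC(=O)N(c2cnc(NCc3c(F)ccc4c3CCO4)n3cnnc23)C1` gives 200000 nM in this assay, the only true number so far. Compound 3 `O=C1CCCN1c1cnc(NCc2c(F)ccc3c2CCO3)n2cnnc12` differs from compound 2 by hydrogen in place of methyl on a saturated ring carbon, so 4-methyl-2-oxopyrrolidin-1-yl becomes 2-oxopyrrolidin-1-yl.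

For the measured compounds named here, the one measured step bearing on this is large: an at least 200-fold higher number from compound 1 to compound 2 (2.30 log units; beyond the scatter). It exchanges the whole phenylcarbamoyl group, and its size rests on (the limit of < 1000 nM in this assay, at which 1 of the 2 values shown sits). Going by the values given here, no measured step isolates the methyl, so that step gives no size for this much smaller change. The expected result in this assay is a 1.3-fold higher number from compound 2 to compound 3 (0.10 log units; within the scatter), with no shift beyond the scatter anticipated. For compound 3 the estimated value is 250000 nM, with an expected range of 100000 nM to 500000 nM.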

Compound 3, solubility: 640000 nM
Compound 3: the middle estimate sits 2.6-fold (0.41 log units) below what was measured, outside the stated range (above it).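

In this assay, hydrogen in place of methyl on a saturated ring carbon of the five-membered ring, two ring bonds from the ring nitrogen, gives a 3.2-fold higher number from compound 2 to compound 3 (0.51 log units; beyond the scatter), so a change of one heavy atom at this position moves the number beyond the scatter. With 2-oxopyrrolidin-1-yl in place of phenylcarbamoyl on an aromatic carbon, the comparison reads an at least 640-fold higher number from compound 1 to compound 3 (2.80 log units; beyond the scatter). The value of compound 1 is a limit of the assay and not a number: the limit of < 1000 nM in this assay, at which 1 of the 3 values shown sits.

The compounds shown leave open how the number responds to an ethyl, a hydroxyl or an amine on the same ring carbon. They also leave open whether the opposite methyl stereoisomer would read like compound 2 or like compound 3.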